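Trifluoromethyl Added to the Anilino Side of Compound 2

The source may hold more compounds than are shown below. What is called first, only, known or untested is meant among the compounds shown, and "the series" means these compounds.

Three measured compounds share one core and differ only in the group on the amide-type nitrogen. In a functional assay on MDA-MB-231 cells (Homo sapiens) for inhibition, read by MTT assay, with a stated time of 72 h (a higher number here means a weaker inhibitor, a lower number a stronger inhibitor), compound 1 `O=C(CSc1nc(Nc2ccccc2)c2ccccc2n1)Nc1cccc(Br)c1` gives 17500 nM, compound 2 `C=CC(=O)Nc1cccc(NC(=O)CSc2nc(Nc3ccccc3)c3ccccc3n2)c1` gives 10200 nM, and compound 3 `O=C(CSc1nc(Nc2ccccc2)c2ccccc2n1)Nc1ccc(Cl)c(Cl)c1` gives 14500 nM. Going by the values given here, the steps of a 1.7-fold lower number from compound 1 to compound 2 (0.23 log units; within the scatter), a 1.2-fold lower number from compound 1 to compound 3 (0.08 log units; within the scatter) and a 1.4-fold higher number from compound 2 to compound 3 (0.15 log units; within the scatter) all lie within the scatter, so no compound stands apart from the others. Compound 4 `C=CC(=O)Nc1cccc(NC(=O)CSc2nc(Nc3ccc(C(F)(F)F)cc3)c3ccccc3n2)c1` keeps the amide side of compound 2 unchanged and alters the anilino group instead: trifluoromethyl in place of hydrogen on an aromatic carbon. Among the compounds with values here, none of the measured steps touches this part of the molecule, so the data give no direction to expect, and the estimated step is a 1.0-fold lower number from compound 2 to compound 4 (0.01 log units; within the scatter), nothing beyond the scatter. Compound 4 is therefore expected to give about 10000 nM in this assay, between 4000 nM and 25000 nM.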

Compound 4, half-maximal inhibitory concentration: 11500 nM
Compound 4: the middle estimate sits 1.2-fold (0.06 log units) below what was measured; the range from low to high includes it.
By their numbers in this assay, from the lowest: compounds 2, 4, 3 and 1 (each within the scatter of the next).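

In this assay, trifluoromethyl on an aromatic carbon of the anilino group, para to a large group, gives a 1.1-fold higher number from compound 2 to compound 4 (0.05 log units; within the scatter) and so no readable change. Going by these compounds alone, this shows that a part of the molecule the earlier compounds left untouched can carry these four extra heavy atoms with the number staying within the scatter. No available measurement accounts for this result.

From the compounds shown here alone, whether an amine or a carboxylic acid on the same carbon would also leave the number within the scatter stays open. So does whether a small group such as methyl or fluorine would.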